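Methyl for Trifluoromethyl on a Fused Urea Core

The source may report more compounds than this note shows. Statements on the series, on what has been measured and on what is new or still open speak of the compounds shown alone.

Measured so far in an in vitro functional assay on cells for antagonist activity at transient receptor potential cation channel subfamily V member 1 (Homo sapiens), read by reporter gene assay and calcium flux; on this read-out higher numbers stand for weaker inhibition and lower numbers for stronger inhibition:
Compound 1 `O=C(Nc1ccc(Cl)c(C(F)(F)F)c1)Nc1cccc2cc(O)ccc12`: 18 nM
Compound 2 `O=C(Nc1ccc(Cl)c(C(F)(F)F)c1)Nc1cccc2c(O)cccc12`: 45 nM
Compound 3 `O=C(Nc1ccc(Cl)c(C(F)(F)F)c1)Nc1cccc2nc(C(F)(F)F)[nH]c12`: 32 nM

All three numbers lie within the usual scatter of one another, so compound 3 cannot be told apart from compound 1 or compound 2 on these results.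

Compound 4 `Cc1nc2cccc(NC(=O)Nc3ccc(Cl)c(C(F)(F)F)c3)c2[nH]1` has not yet been tested. It differs from compound 3 in one place: methyl in place of trifluoromethyl on an aromatic carbon. Going by the values given here, no measured pair shows this change, so no size of step is known for it.

In this assay compound 4 is expected to give a number near that of compound 3, perhaps a little higher, with a 1.9-fold higher number from compound 3 to compound 4 (0.27 log units; within the scatter) as the estimated step, a step that may not exceed the scatter. The estimate for compound 4 is 60 nM, within a range from 20 nM to 200 nM.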

Compound 4, half-maximal inhibitory concentration: 58 nM
The estimate for compound 4 lay 1.0-fold (0.01 log units) above the measured number; measured number inside the range.
By their numbers in this assay, from the lowest: compounds 1, 3, 2 and 4 (each within the scatter of the next, the first and the last beyond it).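

In this assay, the change from trifluoromethyl to methyl on this aromatic carbon, between two ring nitrogen atoms, now has a measured size: a 1.8-fold higher number from compound 3 to compound 4 (0.26 log units; within the scatter). On this read-out, the two groups cannot be told apart at this position, even though methyl lacks the 3 fluorine atoms. No measurement shown here explains this result.

On these data alone, whether a hydrogen atom, an ethyl chain or an amine at this position would also stay within the scatter of compound 3 remains open. So does whether the same change would give a similar step on another core.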